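The source may report more compounds than this note shows. Statements on the series, on what has been measured and on what is new or still open speak of the compounds shown alone.

Compound 1 `Cn1cncc1CN1CC(N(CC2CCN(C(=O)C3CCCC3)CC2)S(=O)(=O)c2ccccn2)Cc2cc(C#N)ccc21` gives 0.5 10^-6 cm/s in an ADME assay on Caco-2 cells (Homo sapiens) for permeability, in the apical to basolateral direction; a lower number here means that the compound crosses the layer more slowly, a higher number that the compound crosses the layer faster.
Compound 2 `Cn1cncc1CN1CC(N(CC2CCN(C(=O)CC(F)(F)F)CC2)S(=O)(=O)c2ccccn2)Cc2cc(C#N)ccc21` gives 0.5 10^-6 cm/s in this assay.
Compound 3 `CCOC(=O)N1CCC(CN(C2Cc3cc(C#N)ccc3N(Cc3cncn3C)C2)S(=O)(=O)c2ccccn2)CC1` gives 2.6 10^-6 cm/s in this assay.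

Compound 2 sits level with compound 1 at the digits printed, and together these two are the lowest of the three numbers; compound 3 stands apart from both, with a 5.2-fold higher number from compound 2 to compound 3 (0.72 log units; beyond the scatter) and a 5.2-fold higher number from compound 1 to compound 3 (0.72 log units; beyond the scatter). The step from compound 1 to compound 2, no change at the digits printed from compound 1 to compound 2 (within the scatter), shows that swapping cyclopentyl for 2,2,2-trifluoroethyl on the carbonyl carbon left the number where it was.

Compound 4 `CC(C)OC(=O)N1CCC(CN(C2Cc3cc(C#N)ccc3N(Cc3cncn3C)C2)S(=O)(=O)c2ccccn2)CC1` differs from compound 2 by isopropoxy in place of 2,2,2-trifluoroethyl on a carbonyl carbon. The closest guide is the step from compound 2 to compound 3, where ethoxy replaced 2,2,2-trifluoroethyl on the same carbonyl carbon and gave a 5.2-fold higher number from compound 2 to compound 3 (0.72 log units; beyond the scatter). For the measured compounds named here, the change to compound 4 puts isopropoxy there instead, so the same kind of step is expected, in the direction of a higher number, and of roughly the size seen with ethoxy, since no measured pair separates ethoxy from isopropoxy.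

Compound 4 is therefore expected to show a 6.0-fold higher number from compound 2 to compound 4 (0.78 log units; beyond the scatter) in this assay. For compound 4 the estimate is 3 10^-6 cm/s, expected to fall between 1.3 10^-6 cm/s and 7 10^-6 cm/s.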

Compound 4, apparent permeability: 1 10^-6 cm/s
Compound 4: middle estimate off by 3.0-fold (0.48 log units), on the high side; measured number outside the range, below it.
By their numbers in this assay, from the lowest: compounds 1, 2 and 4 (each within the scatter of the next); then compound 3.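

With isopropoxy on the carbonyl carbon, compound 4 stays close to the two compounds without an oxygen at this place in this assay: there is a 2.0-fold higher number from compound 2 to compound 4 (0.30 log units; within the scatter) and a 2.0-fold higher number from compound 1 to compound 4 (0.30 log units; within the scatter), so an oxygen attached to this carbonyl carbon does not by itself bring the number to the level of compound 3. The step between the two oxygen-linked groups is the new finding, since one methyl in place of hydrogen, turning ethoxy into isopropoxy, gives a 2.6-fold lower number from compound 3 to compound 4 (0.41 log units; beyond the scatter), which shows that the number at this position can shift with a small change in the group. Nothing measured here explains why the ethoxy compound stands apart from the other three, so the difference remains an observation without a known cause.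

Compound 3 is the only one of the four that stands apart, and a single compound cannot show whether ethoxy is an isolated high point or part of a wider trend. A methoxy group, a longer chain such as n-propoxy, or an amine such as dimethylamino on the same carbonyl carbon would help to settle that question.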